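A methyl added to a weak growth inhibitor

The source may hold more compounds than are shown below. What is called first, only, known or untested is meant among the compounds shown, and "the series" means these compounds.

Measured in a functional assay on A2780 cells (Homo sapiens) for inhibition, read by sulforhodamine B assay; a lower number here means a stronger inhibitor of growth, a higher number a weaker inhibitor of growth:
- compound 1 `Cc1ccc2[nH]c(-c3ccc(-c4ccc(-c5cccc(Cl)c5)cc4)cc3)nc2c1` gives 2800 nM
- compound 2 `Fc1ccc(-c2ccc(-c3ccc(-c4nc5ccccc5[nH]4)cc3)cc2)cc1` gives 48200 nM

Of these two numbers, compound 2 stands highest at 48200 nM, well beyond the scatter from compound 1. Compound 3 `Cc1ccc2[nH]c(-c3ccc(-c4ccc(-c5ccc(F)cc5)cc4)cc3)nc2c1` differs from compound 2 by methyl in place of hydrogen on an aromatic carbon. For the measured compounds named here, compound 1 also bears this methyl and gives 2800 nM, but it differs elsewhere too, so no measured pair isolates the change. A moderate fall in the number is therefore expected, an estimated 3.2-fold lower number from compound 2 to compound 3 (0.51 log units; beyond the scatter), probably beyond the scatter. For compound 3 the expected value is 15000 nM (estimated range 4000 nM to 50000 nM).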

Compound 3, concentration for 50% growth inhibition: 24600 nM
Beside the measured number, compound 3's estimate is 1.6-fold (0.21 log units) below it; measured number inside the range.
By their numbers in this assay, from the lowest: compound 1; then compounds 3 and 2 (each within the scatter of the next).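

Methyl in place of hydrogen on this aromatic carbon gives a 2.0-fold lower number from compound 2 to compound 3 (0.29 log units; within the scatter), so the change cannot be told from the scatter. For the compounds shown here, with the methyl present in both compounds, 4-fluorophenyl in place of 3-chlorophenyl gives an 8.8-fold higher number from compound 1 to compound 3 (0.94 log units; beyond the scatter), so of the two changes, only this one gives a step beyond the scatter. Nothing available explains either step.

The compounds shown leave open whether an amine or a methoxy group on this same aromatic carbon would give a step beyond the scatter. They also leave open how an amine on the outer phenyl ring would compare with the 3-chlorophenyl of compound 1.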